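The compounds below may be only part of what the source reports. "The series", "measured", "known", "first", "only" and "open" are said of these compounds alone.

Measured so far:
- compound 1, `Nc1scc(CN2CCN(c3cc(Cl)cc(Cl)c3)CC2)c1C(=O)c1ccc(Cl)cc1`: -74%
- compound 2, `Nc1scc(CN2CCN(c3cccnc3)CC2)c1C(=O)c1ccc(Cl)cc1`: -23%

In a functional assay on CHO cells with adenosine receptor A1 (Homo sapiens) as the target, read by cAMP accumulation and immunoassay, with a stated time of 6 min, tested at 10 uM (on this read-out higher numbers stand for a weaker effect at the one concentration tested and lower numbers for a stronger effect), compound 2 holds the highest of the two numbers, with compound 1 the nearest at a number 51 percentage points higher from compound 1 to compound 2 (beyond the scatter). Compound 3, `Nc1scc(CN2CCN(c3ccc(F)c(F)c3)CC2)c1C(=O)c1ccc(Cl)cc1`, differs from compound 2 by 3,4-difluorophenyl in place of pyridin-3-yl on an amine nitrogen in a ring. Among the compounds with values here, the only step bearing on it is a number 51 percentage points higher from compound 1 to compound 2 (beyond the scatter), which ran the opposite way, a halogen-bearing phenyl giving way to pyridin-3-yl; here a halogen-bearing phenyl returns, so a large step downward in this assay is expected, back toward the region of compound 1. For compound 3 an estimated -60% (range -85% to -30%) is expected, a step of a number 37 percentage points lower from compound 2 to compound 3 (beyond the scatter).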

Compound 3, a percentage reported as activity, at one concentration (the size of the read-out at that concentration, not a potency): -87%
Beside the measured number, compound 3's estimate is 27 percentage points above it; measured number outside the range, below it.
By their numbers in this assay, from the lowest: compound 3; then compound 1; then compound 2.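

In this assay, 3,4-difluorophenyl in place of pyridin-3-yl on the ring amine nitrogen gives a number 64 percentage points lower from compound 2 to compound 3 (beyond the scatter), so both halogen-bearing phenyls now lie below the pyridin-3-yl compound. The two halogen-bearing phenyls are also not interchangeable, with 3,4-difluorophenyl in place of 3,5-dichlorophenyl giving a number 13 percentage points lower from compound 1 to compound 3 (beyond the scatter), although halogen identity and substitution pattern change together in this step. No measurement given here bears on the cause of either step.

Open, as far as these compounds go, is where unsubstituted phenyl or 4-methoxyphenyl would fall at this position. Also open, from the compounds shown here alone, is whether 3,5-difluorophenyl would separate the halogen's identity from its pattern.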